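The compounds below may be only part of what the source reports. "The series", "measured", "known", "first", "only" and "open" are said of these compounds alone.

Measured compounds in a functional assay on CRL2813 cells (Homo sapiens) for antiproliferative activity, read by sulforhodamine B assay, with a stated time of 5 days; a lower number here means a stronger inhibitor, a higher number a weaker inhibitor:
compound 1 `O=C(Nc1ccc(Cl)c(Cl)c1)Nc1ncccc1O` gives 1600 nM
compound 2 `O=C(Nc1ccc(Cl)c(C(F)(F)F)c1)Nc1ncccc1O` gives 600 nM
compound 3 `COc1cc(NC(=O)Nc2ccc(Cl)c(Cl)c2)ccc1C` gives 500 nM

Compound 1 and compound 2 share a core and differ in one place: trifluoromethyl in place of chloro on an aromatic carbon. That change gives a 2.7-fold lower number from compound 1 to compound 2 (0.43 log units; beyond the scatter).

Compound 3 carries a different core from compound 1; the difference between the two cores is not broken down here. Compound 3 and compound 2 give numbers within the scatter of each other, so no order can be read between them. Compound 3 and compound 1 lie beyond the scatter of each other.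

The unmeasured compound 4 `COc1cc(NC(=O)Nc2ccc(Cl)c(C(F)(F)F)c2)ccc1C` stands to compound 3 as compound 2 stands to compound 1: trifluoromethyl in place of chloro on an aromatic carbon. The surroundings of the place are described in the same words for both pairs, so this is the same change made on a different core. Among the measured compounds shown here, only the one earlier pair shows how large a step this change makes, and whether it carries over to the core of compound 3 is not known.

The step from compound 3 to compound 4 in this assay is expected to be a 2.5-fold lower number from compound 3 to compound 4 (0.40 log units; beyond the scatter), close to the earlier one, because the same change gave a 2.7-fold lower number from compound 1 to compound 2 (0.43 log units; beyond the scatter). Compound 4 is therefore estimated at 200 nM, with a plausible range from 90 nM to 450 nM.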

Compound 4, half-maximal inhibitory concentration: 2800 nM
Compound 4: middle estimate off by 14-fold (1.15 log units), on the low side; the measured number lies above the stated range.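

In this assay, trifluoromethyl in place of chloro gives a 5.6-fold higher number from compound 3 to compound 4 (0.75 log units; beyond the scatter), which runs opposite to the step on the core of compound 1, so the change does not carry over between these two cores: the same change on two cores in this assay, a 2.7-fold lower number (0.43 log units; beyond the scatter) from compound 1 to compound 2 and a 5.6-fold higher number (0.75 log units; beyond the scatter) from compound 3 to compound 4, 15-fold (1.17 log units) apart, beyond the scatter of two such steps

In this series, the direction as well as the size of the step therefore depends on the core, and a step read on one core cannot simply be transferred to the other. The two pairs do not show which difference between the cores sets the direction of the step, and they give no rule for any third core.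

Going by these compounds, it remains open whether a nitrile or a bromo group in the same place would also split the two cores, or whether the reversal is particular to trifluoromethyl. On these data alone, it is also open whether changing a single part of the core of compound 3, for example an amine in place of the methoxy group, would restore the direction seen on the core of compound 1.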